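The source may report more compounds than this note shows. Statements on the series, on what has been measured and on what is new or still open speak of the compounds shown alone.

So far three compounds sharing one core have been measured in a functional assay on NCI-H460 cells (Homo sapiens) for antiproliferative activity, read by CCK-8 assay, with a stated time of 72 h; on this read-out lower numbers stand for stronger inhibition and higher numbers for weaker inhibition. There, compound 1 (`Nc1ccccc1NC(=O)c1ccc(Cn2cnc3c(NCc4ccccc4)nc(Cl)nc32)cc1`) gives 11200 nM and compound 2 (`Nc1ccccc1NC(=O)c1ccc(Cn2cnc3c(Nc4ccc(-c5ccccn5)cc4)nc(Cl)nc32)cc1`) gives 18400 nM while compound 3 (`CC1CCN(c2nc(Cl)nc3c2ncn3Cc2ccc(C(=O)Nc3ccccc3N)cc2)CC1`) gives 7400 nM on the same read-out. That last value lies within the scatter of compound 1 and beyond the scatter from compound 2. Compound 4 (`Nc1ccccc1NC(=O)c1ccc(Cn2cnc3c(Nc4cccc(Cl)c4)nc(Cl)nc32)cc1`) has (3-chlorophenyl)amino in place of 4-methylpiperidin-1-yl on an aromatic carbon and has not yet been measured. Among the compounds with values here, two measured steps bear on this change. At the same carbon, the data show a 1.5-fold lower number from compound 1 to compound 3 (0.18 log units; within the scatter) with 4-methylpiperidin-1-yl in place of benzylamino. Changing the group on the nitrogen gives a 1.6-fold higher number from compound 1 to compound 2 (0.22 log units; within the scatter) with 4-(pyridin-2-yl)phenyl in place of benzyl. Both steps stay within the scatter. Within the data shown here, no measured compound carries the (3-chlorophenyl)amino group, so a small upward move at most is expected, with nothing beyond the scatter. The estimated step is a 1.5-fold higher number from compound 3 to compound 4 (0.17 log units; within the scatter) in this assay on this reasoning. For compound 4 the expected value is 11000 nM with an estimated range from 4500 nM to 25000 nM overall.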

Compound 4, half-maximal inhibitory concentration: 6580 nM
Compound 4: the middle estimate sits 1.7-fold (0.22 log units) above what was measured; measured number inside the range.
By their numbers in this assay, from the lowest: compounds 4, 3, 1 and 2 (each within the scatter of the next, the first and the last beyond it).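

In this assay a non-aromatic ring and a chlorine-bearing aromatic ring prove interchangeable at this carbon: the change gives a 1.1-fold lower number from compound 3 to compound 4 (0.05 log units; within the scatter) even though the entering group brings a hydrogen-bond donor that the leaving group lacks. Among the groups on the nitrogen, 3-chlorophenyl in place of 4-(pyridin-2-yl)phenyl gives the only step here beyond the scatter, a 2.8-fold lower number from compound 2 to compound 4 (0.45 log units; beyond the scatter), while 3-chlorophenyl in place of benzyl gives a 1.7-fold lower number from compound 1 to compound 4 (0.23 log units; within the scatter) and stays within it. Nothing available explains these differences.

Every group shown at this carbon is joined through nitrogen, so the effect of a methoxy group, joined through oxygen, remains open. Also open, as far as these compounds go, is whether an amine could replace the chloro group on the shared core.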